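The compounds below may be only part of what the source reports. "The series", "measured", "known", "first", "only" and "open" are said of these compounds alone.

Measured so far:
- compound 1, `CCCCCCCCNC(=O)[C@@H](NC(=O)c1ccco1)[C@@H](C)O`: 124000 nM
- compound 2, `CCCCCCCCCCCCCCNC(=O)[C@@H](NC(=O)c1ccco1)[C@@H](C)O`: 127000 nM

Both numbers come from a functional assay on SiHa cells (Homo sapiens) for cytotoxicity, read by MTT assay, with a stated time of 48 h; on this read-out higher numbers stand for weaker inhibition and lower numbers for stronger inhibition. Within the data shown here, compound 2 sits together with compound 1; the only measured step, a 1.0-fold higher number from compound 1 to compound 2 (0.01 log units; within the scatter), concerns chain length alone, so the two compounds are not separated by this assay.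

Compound 3, `CCCCCCCCCCCCCCNC(=O)[C@@H](NS(=O)(=O)c1ccc(C)cc1)[C@@H](C)O`, differs from compound 2 in one place: (4-methylphenyl)sulfonyl in place of (furan-2-yl)carbonyl on an amine nitrogen. Among the measured compounds shown here, none of the measured steps bears on this exchange; the single step, a 1.0-fold higher number from compound 1 to compound 2 (0.01 log units; within the scatter), touches only the chain and says nothing about the acyl group on the amine nitrogen. There is therefore no measured basis for a direction. The working expectation is that compound 3 stays near compound 2, with a 1.1-fold lower number from compound 2 to compound 3 (0.02 log units; within the scatter) as the estimated step, and with wide uncertainty on either side since an unrelated change on the amine nitrogen has not yet been tested in this series. Compound 3 is expected at 120000 nM in this assay, in the range 40000 nM to 300000 nM.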

Compound 3, half-maximal inhibitory concentration: 19200 nM
The estimate for compound 3 lay 6.3-fold (0.80 log units) above the measured number; the whole stated range lies above it.
By their numbers in this assay, from the lowest: compound 3; then compounds 1 and 2 (each within the scatter of the next).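

In this assay, among these compounds, the amine nitrogen is the first place where a single change separates two compounds: (4-methylphenyl)sulfonyl in place of (furan-2-yl)carbonyl gives a 6.6-fold lower number from compound 2 to compound 3 (0.82 log units; beyond the scatter), a modest step beyond the scatter, whereas the chain change gave a 1.0-fold higher number from compound 1 to compound 2 (0.01 log units; within the scatter), which lies within it. This position therefore responds in this assay, with the lower number standing for stronger inhibition, although the evidence is one pair and the exchange replaces the five-membered aromatic ring and the carbonyl in a single move. Nothing measured accounts for the size or direction of this step.

The compounds shown leave open whether the step follows the sulfonyl or the six-membered aromatic ring, a question that a plain benzoyl group or a (furan-2-yl)sulfonyl group on the same nitrogen would address. Also open is whether the chain stays without effect once the sulfonyl group is present, as the shorter chain of compound 1 is shown only with (furan-2-yl)carbonyl.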